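The source may report more compounds than this note shows. Statements on the series, on what has been measured and on what is new or still open speak of the compounds shown alone.

Compound 1 `O=C(OC1CCC(CN2CCN(c3cc(=O)c4cc(C(F)(F)F)cc([N+](=O)[O-])c4s3)CC2)CC1)C1CCCCC1` — in an ADME assay on Vero cells (Chlorocebus sabaeus) for cytotoxicity, read by MTT assay, with a stated time of 48 h (a lower number here means a stronger inhibitor, a higher number a weaker inhibitor), compound 1 gives > 64 ug/mL, a limit of the assay.
Compound 2 `O=C(OC1CCC(CN2CCN(c3cc(=O)c4cc(C(F)(F)F)cc([N+](=O)[O-])c4s3)CC2)CC1)c1ccco1` — compound 2 gives > 64 ug/mL, likewise a limit.
Compound 3 `CS(=O)(=O)NC1CCC(CN2CCN(c3cc(=O)c4cc(C(F)(F)F)cc([N+](=O)[O-])c4s3)CC2)CC1` — compound 3 gives 48.5 ug/mL.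

Compound 1 thus stands only at a limit, not at a measured number; it shares that position with compound 2, as the limit of > 64 ug/mL in this assay, at which 2 of the 3 values shown sit, records, so where compound 1 falls relative to the others cannot be read from the numbers. The step that the two limits leave unreadable from compound 1 to compound 2 is therefore unreadable. The steps of an at least 1.3-fold lower number from compound 1 to compound 3 (0.12 log units; that floor lies within the scatter) and an at least 1.3-fold lower number from compound 2 to compound 3 (0.12 log units; that floor lies within the scatter) do reach a measured number for compound 3, but the floor of each lies within the scatter, so neither shows a real change.

Compound 4 `O=c1cc(N2CCN(CC3CCC(OS(=O)(=O)c4ccccc4)CC3)CC2)sc2c([N+](=O)[O-])cc(C(F)(F)F)cc12` differs from compound 1 by phenylsulfonyl in place of cyclohexylcarbonyl on an oxygen on a saturated carbon. Going by the values given here, no measured step makes a change of this kind, and the only steps that can be read at all stay within the scatter, so in this assay no step beyond the scatter is expected in either direction. Compound 4 is accordingly expected to give 64 ug/mL, within 40 ug/mL to 110 ug/mL, a step of a number no higher from compound 1 to compound 4 (the limit leaves the size open), and most likely again to be reported only as a limit.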

Compound 4, half-maximal inhibitory concentration: > 64 ug/mL
Compound 4: a limit, no number; the forecaster's own chance of this, stated with the estimate: 65%; the middle value lies on the limit itself.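

In this assay compound 4, with (phenylsulfonyl)oxy on the saturated ring carbon, gives > 64 ug/mL, which is a limit and not a number. This position thus carries a sulfonyl group on its oxygen as well as the two carbonyl groups seen earlier, and the reading against the methanesulfonamido group is an at least 1.3-fold higher number from compound 3 to compound 4 (0.12 log units; that floor lies within the scatter), so no real change is shown. The steps from compound 1 and from compound 2 to compound 4 cannot be read, because all three compounds rest at one limit: the limit of > 64 ug/mL in this assay, at which 3 of the 4 values shown sit.

From the compounds shown here alone, how far compound 1, compound 2 and compound 4 lie apart remains unknown, since none of them has a measured number here. Also open, going by these compounds, is whether an amine or a carboxylic acid at this position would give a number clearly apart from that of compound 3.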